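The source may hold more compounds than are shown below. What is called first, only, known or untested is meant among the compounds shown, and "the series" means these compounds.

The shared core is carried by compound 1 `COCc1nc(C)c2cnnc(S)n12` and compound 2 `Cc1ncn2c(S)nncc12`, which differ only at one aromatic carbon. In a functional assay for inhibition, with Homo sapiens as the target (on this read-out higher numbers stand for weaker inhibition and lower numbers for stronger inhibition), compound 1 gives > 48000 nM, which is a limit of the assay rather than a number. In this assay compound 2 likewise gives only a limit, > 48000 nM. Compound 2 therefore stands exactly where every measured value sits, namely (the limit of > 48000 nM in this assay, at which 2 of the 2 values shown sit), and no number separates it from compound 1. The step that the two limits leave unreadable from compound 1 to compound 2 is consequently unreadable in size and direction.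

Compound 3 `CCCc1nc(C)c2cnnc(S)n12` differs from compound 2 by propyl in place of hydrogen on an aromatic carbon. Going by the values given here, the only measured step touching this carbon is the one from compound 1 to compound 2, and it cannot be read, so the measured compounds give no readable change at this position on which to build. The change in compound 3 is expected to leave the result in this assay at or near the limit, with a step of a number no higher from compound 2 to compound 3 (the limit leaves the size open) expected to remain within the scatter. Compound 3 is therefore estimated at 48000 nM in this assay, within a range from 20000 nM to 200000 nM.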

Compound 3, half-maximal inhibitory concentration: 10000 nM
Beside the measured number, compound 3's estimate is 4.8-fold (0.68 log units) above it; measured number outside the range, below it.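

Propyl in place of hydrogen on the aromatic carbon between two ring nitrogen atoms gives, in this assay, an at least 4.8-fold lower number from compound 2 to compound 3 (0.68 log units; beyond the scatter), so this position, where the earlier compounds offered no readable change, can carry a change beyond the scatter. On the saturated chain carbon bound to that same aromatic carbon, ethyl in place of methoxy gives an at least 4.8-fold lower number from compound 1 to compound 3 (0.68 log units; beyond the scatter), so the propyl of compound 3 and the methoxymethyl of compound 1 do not behave alike in this assay. Going by these compounds alone, compound 1 and compound 2 each still give only a limit of the assay, not a number, which makes compound 3 the sole compound here with a measured number: the limit of > 48000 nM in this assay, at which 2 of the 3 values shown sit.

On these data alone, the true size of both new steps stays open, as each is bounded on one side only, and the step between compound 1 and compound 2 still cannot be read. The compounds shown also leave open whether a longer chain such as butyl, a ring such as cyclopropyl, or an amine at the end of the chain would take the number lower than in compound 3 or return it to the limit.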